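Two inactive amides and a tetrahydroisoquinoline analogue

This account rests on a few compounds, and the source may have more. Where it says the series, first, only, none or still open, it means among the compounds named here.

Compound 1 `CS(=O)(=O)c1ccc(C(=O)N2CCC(C(=O)N(Cc3ccccc3)c3ccccc3)CC2)cc1[N+](=O)[O-]`: > 60000 nM
Compound 2 `CCCN(C(=O)CN(C)C(=O)c1ccc(S(C)(=O)=O)c([N+](=O)[O-])c1)c1ccccc1`: > 60000 nM

In an assay on isolated protein for inhibition of vitamin D3 receptor (Homo sapiens), read by fluorescence polarization (a higher number here means a weaker inhibitor, a lower number a stronger inhibitor), compound 1 reaches only a limit of the measurement, > 60000 nM. Compound 2 likewise gives only a limit, > 60000 nM, so no true number is known for it. The single thing shown is the limit of > 60000 nM in this assay, at which 2 of the 2 values shown sit. Compound 3 `CN(CC(=O)N1CCc2ccccc2C1)C(=O)c1ccc(S(C)(=O)=O)c([N+](=O)[O-])c1` carries 1,2,3,4-tetrahydroisoquinolin-2-yl in place of phenyl(propyl)amino on a carbonyl carbon. Among the compounds with values here, with no measured step to draw on, the expected step from compound 2 to compound 3 is a step that the limit leaves unreadable from compound 2 to compound 3, nothing beyond the scatter. Compound 3 is therefore estimated at 80000 nM, within 20000 nM to 300000 nM, most likely again reported only as a limit.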

Compound 3, half-maximal inhibitory concentration: > 60000 nM
Compound 3 was reported as a limit; the forecaster's own chance of this, stated with the estimate: 85%; the middle value does not contradict the limit.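

No size can be read for the step from compound 2 to compound 3, since both are reported only as limits: the limit of > 60000 nM in this assay, at which 3 of the 3 values shown sit.

The compounds shown leave open which change to the shared core, if any, would give a true number rather than a limit.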